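Imidazoline to Imidazole on a Diaryl Thioether Scaffold

The compounds below may be only part of what the source reports. "The series", "measured", "known", "first", "only" and "open" are said of these compounds alone.

Compound 1 `COc1ccc(Sc2ccc(NC3=NCCN3)cc2)cc1` carries a cyclic amidine attached through a nitrogen and in an assay (Rattus norvegicus) for binding affinity to prostacyclin receptor (Homo sapiens), read by radioligand binding (a lower number here means a stronger inhibitor, a higher number a weaker inhibitor), gives 50.1 nM; 50.1 nM (2 entries). For the measured compounds named here, compound 2 `COc1ccc(Sc2ccc(C3=NCCN3)cc2)cc1` attaches the same five-membered ring directly by carbon, and in this assay compound 2 gives 316 nM, the only number recorded for it, alongside one further entry that yielded no single figure. Compound 3 `COc1ccc(Sc2ccc(-c3ncc[nH]3)cc2)cc1` is the next step, not yet measured; it differs from compound 2 by a group of 5 heavy atoms (3 carbon, 2 nitrogen; one five-membered aromatic ring with 2 hetero atoms) in place of a group of 5 heavy atoms (3 carbon, 2 nitrogen; one five-membered non-aromatic ring with 2 hetero atoms), on an aromatic carbon. Going by the values given here, no step between measured compounds is available to calibrate such an exchange. The account expects the change to weaken binding by a margin beyond the usual scatter, since the ring that enters has one fewer acceptor and has become aromatic. Compound 3 is therefore expected to reach 1500 nM in this assay, within 300 nM to 8000 nM, a step of a 4.7-fold higher number from compound 2 to compound 3 (0.68 log units; beyond the scatter) that is only an estimate.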

Compound 3, inhibition constant: < 10000 nM
Compound 3: a limit, no number; the forecaster's own chance of this, stated with the estimate: 20%; the middle value does not contradict the limit.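

In this assay, for the compounds shown here, compound 3 gives < 10000 nM, a limit and not a number, and no step from compound 2 to compound 3 can be read from it. The compounds shown leave open whether the 1H-imidazol-2-yl group of compound 3 weakens binding, strengthens it or leaves it unchanged relative to compound 2.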